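The source may report more compounds than this note shows. Statements on the series, on what has been measured and on what is new or still open speak of the compounds shown alone.

Measured in a functional assay on cells (Erythrocyte, Rattus norvegicus) for inhibition, read by hemolysis, with a stated time of 1 h; a lower number here means a stronger inhibitor, a higher number a weaker inhibitor:
- compound 1 `COc1cc(OC)c(OC)cc1/C=C/C(=O)c1cc(Cc2ccccc2)cc(Cc2ccccc2)c1`: 2.17 ug/mL
- compound 2 `COc1cc(OC)c(OC)cc1/C=C/C(=O)c1ccc(-c2c[nH]cn2)cc1`: 2.48 ug/mL
- compound 3 `COc1cc(OC)c(-c2cc(=O)c3cc(Cl)ccc3o2)cc1OC`: 2.13 ug/mL

In this assay the three compounds cannot be told apart. Compound 2, at 2.48 ug/mL, lies within the scatter of both other compounds, so none of them can be ranked as a stronger or weaker inhibitor.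

The next compound is compound 4 `COc1cc(OC)c(OC)cc1/C=C/C(=O)c1ccc(F)cc1`. It keeps the rest of compound 2 but carries fluoro in place of 1H-imidazol-4-yl on an aromatic carbon. The change sits on a six-membered aromatic ring of carbon only. Going by the values given here, no two measured compounds differ in one place alone, so the effect of a single change has not been observed in this set. Among the compounds with values here, the only guide is the narrow spread of values from visibly different structures: compound 1 gives 2.17 ug/mL and compound 3 gives 2.13 ug/mL. On that thin evidence, no change beyond the scatter is expected in this assay, and no direction is favoured. The expected result is a 1.0-fold lower number from compound 2 to compound 4 (0.01 log units; within the scatter). For compound 4 the estimated value is 2.4 ug/mL, with an expected range from 1.1 ug/mL to 5.2 ug/mL.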

Compound 4, half-maximal inhibitory concentration: 2.22 ug/mL
Beside the measured number, compound 4's estimate is 1.1-fold (0.03 log units) above it; the range from low to high includes it.
By their numbers in this assay, from the lowest: compounds 3, 1, 4 and 2 (each within the scatter of the next).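

In this assay, going by these compounds alone, this is the first comparison in the set between two compounds that differ in one place, and it gives a 1.1-fold lower number from compound 2 to compound 4 (0.05 log units; within the scatter). Fluoro can therefore stand in place of 1H-imidazol-4-yl on this aromatic carbon, para to a large group, with no change beyond the scatter, even though the step removes a five-membered aromatic ring with 2 hetero atoms, along with its hydrogen-bond donor and acceptor, and leaves a single fluorine. No measured finding among the compounds shown explains why the number holds at this position, so the result stands as an observation on one pair.

As far as these compounds go, it remains open whether other groups at this position, such as an amine, a carboxylic acid or a longer alkyl chain, would also stay within the scatter of compound 2 and compound 4. It is equally open whether the same exchange would hold on a different core, such as that of compound 3, which has no one-place partner among the compounds shown.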